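Allyl in Place of Methyl on the Sulfur

This account rests on a few compounds, and the source may have more. Where it says the series, first, only, none or still open, it means among the compounds named here.

Three compounds share one core. Compound 1 `CSc1nc(NC(C)=O)nc2c1ncn2[C@H]1C[C@H](O)[C@@H](CO)O1` carries an acetylated amine; in a functional assay on L1210 cells (Mus musculus) for inhibition, read by thymidine incorporation (a higher number here means that more compound is needed for the effect, a lower number that less compound is needed), compound 1 gives "not determined" (no result reported). Compound 2 `CSc1nc(N)nc2c1ncn2[C@@H]1C[C@H](O)[C@@H](CO)O1` has a free amine, and in this assay compound 2 reaches only a limit of the measurement, > 100 uM. Compound 3 `CSc1nc(N)nc2c1ncn2[C@H]1C[C@H](O)[C@@H](CO)O1` has the same atoms and bonds as compound 2 and differs only in configuration at one saturated ring carbon; in this assay compound 3 gives 27 uM. Going by the values given here, the measured step of an at least 3.7-fold lower number from compound 2 to compound 3 (0.56 log units; beyond the scatter) is the one change with a number on both sides, and it rests on (the fact that compounds 2 and 3 differ only in the configuration as drawn). Compound 3 therefore holds the only plain number shown, with one further value being a limit and one entry without a number.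

Compound 4 `C=CCSc1nc(N)nc2c1ncn2[C@H]1C[C@H](O)[C@@H](CO)O1` differs from compound 3 by vinyl in place of hydrogen on a saturated chain carbon bound to a sulfur. Among the compounds with values here, no measured step touches the sulfur substituent: the single measured step concerns configuration only. For this assay, the step from compound 3 to compound 4 is therefore expected to be no change at the digits printed from compound 3 to compound 4 (within the scatter), with no clear direction. The expected value for compound 4 is estimated as 27 uM, within a range from 8 uM to 100 uM.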

Compound 4, concentration for half-maximal effect: 5.5 uM
Compound 4: the middle estimate sits 4.9-fold (0.69 log units) above what was measured, and the stated range ends above it.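

In this assay, going by these compounds alone, the change from methyl to allyl on the sulfur comes with a 4.9-fold lower number from compound 3 to compound 4 (0.69 log units; beyond the scatter) and is the first measured step at this position. Within the data shown here, the only earlier step with a number on both sides concerned configuration at a saturated ring carbon, leaving the group on the sulfur untested. With the rest of compound 3 held fixed, the new pair shows that this read-out responds to the sulfur substituent, and that the allyl group needs less compound than the methyl group for the same effect.

A single pair cannot separate the contribution of the double bond from that of the longer chain, and a saturated propyl group, a benzyl group or a longer chain on the sulfur would be needed to tell how far this trend extends. Nothing among the facts available bears on why the allyl group gives the lower number.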